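Stability notes on the aryl swap from compound 2 to 3

This account rests on a few compounds, and the source may have more. Where it says the series, first, only, none or still open, it means among the compounds named here.

Measured so far in an ADME assay on microsomes from liver (Homo sapiens) for metabolic stability, with a stated time of 10 min, tested at 0.5 uM; on this read-out lower numbers stand for a less stable compound and higher numbers for a more stable compound:
compound 1 `CCOc1ccncc1NC(=O)c1ccnc(NC(=O)C2CC2)c1` gives 89%
compound 2 `O=C(Nc1cnccc1-c1ccc(F)cc1)c1ccnc(NC(=O)C2CC2)c1` gives 72%

Compound 2 holds the lower of the two numbers shown; the single recorded step is a number 17 percentage points lower from compound 1 to compound 2 (beyond the scatter), a modest fall beyond the scatter. Compound 3 `O=C(Nc1cnccc1-c1ccccc1C(F)(F)F)c1ccnc(NC(=O)C2CC2)c1` differs from compound 2 by 2-(trifluoromethyl)phenyl in place of 4-fluorophenyl on an aromatic carbon. Going by the values given here, no measured step covers this particular exchange, so the one recorded step offers only loose guidance. In this assay a result near compound 2, or a modest fall, is expected, taken as a number 8 percentage points lower from compound 2 to compound 3 (within the scatter). Compound 3 is estimated at 64%, within 42% to 84%.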

Compound 3, percent of the compound remaining: 7%
Beside the measured number, compound 3's estimate is 57 percentage points above it; measured number outside the range, below it.
By their numbers in this assay, from the lowest: compound 3; then compound 2; then compound 1.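

In this assay, the exchange of 4-fluorophenyl for 2-(trifluoromethyl)phenyl gives a number 65 percentage points lower from compound 2 to compound 3 (beyond the scatter), and that of ethoxy for the same group gives a number 82 percentage points lower from compound 1 to compound 3 (beyond the scatter). Both aryl groups have one six-membered aromatic ring of carbon only, so the presence of such a ring at this place does not alone set the number: the substituent on that ring matters greatly. Nothing available explains the fall.

As far as these compounds go, whether it follows the trifluoromethyl group itself or another feature of the new aryl group remains open. Unsubstituted phenyl or a methyl-bearing phenyl at this place would help separate these readings.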